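A few compounds are considered here, and "the series" means these few. Any claim that something is new, unique, unknown or untested is made for them only; others in the source may bear on it.

Measured so far:
compound 1, `Oc1ccc(-c2cc(-c3cccnc3)nc(-c3ccccc3Cl)c2)cc1` — in a functional assay on HCT-15 cells (Homo sapiens) for cytotoxicity, read by CCK-8 assay and cell counting, with a stated time of 2 days (a lower number here means a stronger inhibitor, a higher number a weaker inhibitor), compound 1 gives "not determined" (no result reported)
compound 2, `Oc1cccc(-c2cc(-c3ccco3)nc(-c3ccccc3Cl)c2)c1` — 2230 nM
compound 3, `Oc1ccc(-c2cc(-c3cccs3)nc(-c3ccccc3Cl)c2)cc1` — 5430 nM

Compound 3 carries the highest number of the two values in this assay; its nearest neighbour is compound 2, whose number is lower, and that gap lies beyond the scatter. Compound 1 has no result in this assay.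

Compound 4, `Oc1ccc(-c2cc(-c3ccco3)nc(-c3ccccc3Cl)c2)cc1`, differs from compound 3 in one place: furan-2-yl in place of thiophen-2-yl on an aromatic carbon. Going by the values given here, no step between measured compounds matches this change, so its size is not known from the series. Compound 4 is expected to give a step of a 1.6-fold lower number from compound 3 to compound 4 (0.19 log units; within the scatter), most likely none beyond the scatter, with a slight lean toward a lower number. For compound 4 the estimated value is 3500 nM, within 1500 nM to 9000 nM.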

Compound 4, half-maximal inhibitory concentration: 5460 nM
Compound 4: middle estimate off by 1.6-fold (0.19 log units), on the low side; the range from low to high includes it.
By their numbers in this assay, from the lowest: compound 2; then compounds 3 and 4 (each within the scatter of the next).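

In this assay, furan-2-yl in place of thiophen-2-yl next to the ring nitrogen gives a 1.0-fold higher number from compound 3 to compound 4 (0.00 log units; within the scatter) and so no change beyond the scatter for this exchange of hetero atom. With furan-2-yl held constant, 4-hydroxyphenyl in place of 3-hydroxyphenyl gives a 2.4-fold higher number from compound 2 to compound 4 (0.39 log units; beyond the scatter) and so a modest step beyond the scatter. Nothing available explains either result.

Open, going by these compounds, is whether the hydroxyphenyl step holds with thiophen-2-yl in place of furan-2-yl. Also open, on these data alone, is how an amine or a carboxylic acid on the five-membered ring would read.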